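Lengthening the acid chain of compound 2

A few compounds are considered here, and "the series" means these few. Any claim that something is new, unique, unknown or untested is made for them only; others in the source may bear on it.

Among the measured compounds shown here, in a functional assay on HeLa cells (Homo sapiens) for cytotoxicity, read by MTT assay, with a stated time of 48 h (on this read-out lower numbers stand for stronger inhibition and higher numbers for weaker inhibition), compound 2 `Cc1ccc(Cn2c(/C=C3\SC(=S)N(CC(=O)O)C3=O)nc3ccccc32)cc1` gives 1280 nM, the lowest number measured so far. Compound 3 `O=C(O)CN1C(=O)/C(=C/c2nc3ccccc3n2Cc2ccc(C(F)(F)F)cc2)SC1=S` gives 21400 nM. Compound 1 `O=C(O)CN1C(=O)/C(=C/c2nc3ccccc3n2Cc2ccc(Br)cc2F)SC1=S` gives only a limit, > 50000 nM.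

Compound 4 `Cc1ccc(Cn2c(/C=C3\SC(=S)N(CCC(=O)O)C3=O)nc3ccccc32)cc1` changes a different place, a saturated chain carbon bound to an amide-type nitrogen in a ring: carboxymethyl in place of carboxy on a saturated chain carbon bound to an amide-type nitrogen in a ring. Carboxymethyl stands in place of carboxy, which turns the chain from carboxymethyl to 2-carboxyethyl.

The measured steps are large, an at least 39-fold lower number from compound 1 to compound 2 (1.59 log units; beyond the scatter) and a 17-fold higher number from compound 2 to compound 3 (1.22 log units; beyond the scatter), but they only exchange the aromatic group, so neither measures this change directly. A much smaller step is therefore expected in this assay, with a somewhat higher number, though the direction is uncertain. The expected step is estimated as a 1.6-fold higher number from compound 2 to compound 4 (0.19 log units; within the scatter). The estimated value for compound 4 is 2000 nM, with an expected range from 500 nM to 8000 nM.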

Compound 4, half-maximal inhibitory concentration: 11200 nM
For compound 4 the middle estimate is 5.6-fold (0.75 log units) below the measured one, and the stated range ends below it.
By their numbers in this assay, from the lowest: compound 2; then compounds 4 and 3 (each within the scatter of the next). At a limit, above all of these: compound 1.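

In this assay, lengthening the acid chain from carboxymethyl to 2-carboxyethyl gives an 8.8-fold higher number from compound 2 to compound 4 (0.94 log units; beyond the scatter) and so weakens inhibition. Among the compounds shown here, the earlier steps changed only the aromatic group, so this is the first sign that the acid chain also affects the result, even with the aromatic group held as in compound 2. The data shown give no explanation for this loss.

Still open, going by these compounds, is whether a longer chain, or a methyl ester in place of the carboxylic acid, would weaken inhibition further. On these data alone, whether the same lengthening has a similar effect with the aromatic group of compound 3 also remains open.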